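The source may report more compounds than this note shows. Statements on the series, on what has been measured and on what is new or still open speak of the compounds shown alone.

Measured compounds:
Compound 1 `CC1(C)O[C@H]2O[C@H](Cn3cc(CN4C(=O)/C(=N\Nc5ccc(F)cc5)c5ccccc54)nn3)[C@H](O)[C@H]2O1` gives 83800 nM
Compound 2 `COc1ccc(N/N=C2\C(=O)N(Cc3cn(O[C@@H]4O[C@H](CO)[C@H](O)[C@H](O)[C@H]4O)nn3)c3ccccc32)cc1` gives 76200 nM

Both compounds were tested in an ADME assay on Vero cells (Chlorocebus sabaeus) for cytotoxicity, read by fluorescence and resazurin assay, with a stated time of 3 days; a lower number here means that less compound is tolerated, a higher number that more compound is tolerated. Compound 2 gives 76200 nM, and compound 1 gives 83800 nM; the two values lie within the scatter of each other, so the measurements say nothing about a difference between them in this assay. Among the compounds with values here, compound 2 and compound 1 differ at more than one place, and no step between them is counted here.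

Compound 3 `O=C1/C(=N\Nc2ccc(F)cc2)c2ccccc2N1Cc1cn(O[C@@H]2O[C@H](CO)[C@H](O)[C@H](O)[C@H]2O)nn1` has not yet been measured in this assay. Its change against compound 2 is fluoro in place of methoxy on an aromatic carbon. Compound 1 already carries the fluoro group on the same part of the molecule, and its value in this assay sits within the scatter of compound 2, so no change in tolerated concentration beyond the scatter is expected from this step. The step from compound 2 to compound 3 is estimated as a 1.0-fold higher number from compound 2 to compound 3 (0.02 log units; within the scatter). On that basis compound 3 is expected to give about 80000 nM in this assay, with a likely range from 40000 nM to 160000 nM.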

Compound 3, half-maximal cytotoxic concentration: 92100 nM
Beside the measured number, compound 3's estimate is 1.2-fold (0.06 log units) below it, and the stated range covers the measured number.
By their numbers in this assay, from the lowest: compounds 2, 1 and 3 (each within the scatter of the next).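

In this assay the exchange of 4-methoxyphenyl for 4-fluorophenyl gives a 1.2-fold higher number from compound 2 to compound 3 (0.08 log units; within the scatter) and so stays within the scatter, which shows that on this aromatic carbon, para to a large group, fluoro and methoxy cannot be told apart in this read-out. With the fluoro group held the same, the group of 12 heavy atoms with one six-membered non-aromatic ring, in place of the group of 12 heavy atoms with two five-membered non-aromatic rings on an aromatic nitrogen, gives a 1.1-fold higher number from compound 1 to compound 3 (0.04 log units; within the scatter) and is likewise within the scatter, so neither of the two places has yet produced a difference the assay can resolve. Nothing measured on these compounds speaks to why the numbers lie so close together.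

The compounds shown leave open whether an amine or a carboxylic acid in place of fluoro on that aromatic carbon would give a number beyond the scatter. They also leave open whether a longer chain without a ring, in place of the ring-bearing groups on the aromatic nitrogen, would do so.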